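Trimethoxyphenyl series: indolyl to methylphenyl

This account rests on a few compounds, and the source may have more. Where it says the series, first, only, none or still open, it means among the compounds named here.

Measured compounds:
compound 1 `Cn1ccc2cc(-c3cc4nccc(-c5ccc(F)cc5)n4n3)ccc21` gives 4580 nM;
compound 2 `COc1cc(-c2ccnc3cc(-c4ccc5ccn(C)c5c4)nn23)cc(OC)c1OC` gives 74 nM;
compound 3 `COc1cc(-c2ccnc3cc(-c4cccc5c4ccn5CO)nn23)cc(OC)c1OC` gives 1070 nM.

All three numbers come from a functional assay on MCF7 cells (Homo sapiens) for inhibition, read by CCK-8 assay, with a stated time of 48 h; on this read-out lower numbers stand for stronger inhibition and higher numbers for weaker inhibition. Compound 2 stands lowest of the three, with compound 3 the nearest and compound 1 the furthest, both gaps beyond the scatter. Compound 4 `COc1cc(-c2ccnc3cc(-c4cccc(C)c4)nn23)cc(OC)c1OC` is not yet measured in this assay. It differs from compound 2 in one place: 3-methylphenyl in place of 1-methyl-1H-indol-6-yl on an aromatic carbon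

Going by the values given here, no measured pair isolates this change, so the size of the step rests on judgement. The expectation is a weakening, of a size beyond the scatter, an 8.1-fold higher number from compound 2 to compound 4 (0.91 log units; beyond the scatter). Compound 4 is estimated at 600 nM, with a range from 150 nM to 3000 nM.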

Compound 4, half-maximal inhibitory concentration: 1080 nM
Compound 4: the middle estimate sits 1.8-fold (0.26 log units) below what was measured; the measured number falls inside the stated range.
By their numbers in this assay, from the lowest: compound 2; then compounds 3 and 4 (each within the scatter of the next); then compound 1.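

In this assay, going by these compounds alone, 3-methylphenyl in place of 1-methyl-1H-indol-6-yl on this aromatic carbon gives a 15-fold higher number from compound 2 to compound 4 (1.16 log units; beyond the scatter) and is the first step that isolates a single change at this position. With the rest of the molecule held constant, the 3-methylphenyl group does not retain the low number of compound 2, so a simple aromatic ring bearing a methyl does not match the 1-methyl-1H-indol-6-yl group here. No supporting data bear on the reason for this step.

Where an unsubstituted phenyl, a 3-aminophenyl or a 1H-indol-6-yl without the methyl would fall remains open. On these data alone, whether the same step holds on the core of compound 1 also remains open.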